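This account rests on a few compounds, and the source may have more. Where it says the series, first, only, none or still open, it means among the compounds named here.

Measured in a functional assay on MCF7 cells (Homo sapiens) for inhibition, read by CCK-8 assay, with a stated time of 48 h (on this read-out higher numbers stand for weaker inhibition of growth and lower numbers for stronger inhibition of growth), so far
compound 1 `Cc1ccccc1Nc1nc(Nc2ccc(N3CCN(C)CC3)cn2)ncc1Cl` gives 5210 nM
compound 2 `Cc1ccc(CNc2nc(Nc3ccc(N4CCN(C)CC4)cn3)ncc2Cl)cc1` gives 38100 nM
compound 3 `Cc1cccc(Nc2nc(Nc3ccc(N4CCN(C)CC4)cn3)ncc2Cl)c1` gives 7160 nM

Compound 3 stands with compound 1 at the low end of the three numbers: a 1.4-fold higher number from compound 1 to compound 3 (0.14 log units; within the scatter) is the close pairing and a 5.3-fold lower number from compound 2 to compound 3 (0.73 log units; beyond the scatter) is the clear gap. The change to compound 4 `COc1cccc(Nc2nc(Nc3ccc(N4CCN(C)CC4)cn3)ncc2Cl)c1` reads methoxy in place of methyl on an aromatic carbon in short: methoxy in place of methyl on an aromatic carbon, meta to a large group. Among the measured compounds shown here, no measured step makes this exchange. The closest is a 1.4-fold higher number from compound 1 to compound 3 (0.14 log units; within the scatter) with only the methyl moved, while a 7.3-fold higher number from compound 1 to compound 2 (0.86 log units; beyond the scatter) replaces the whole group on nitrogen and says little here. In this assay the expected step is a 1.1-fold lower number from compound 3 to compound 4 (0.04 log units; within the scatter) and none beyond the scatter is expected. The estimate for compound 4 is 6500 nM with an expected range from 3000 nM to 14000 nM as working bounds.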

Compound 4, concentration for 50% growth inhibition: 7540 nM
Compound 4: the middle estimate sits 1.2-fold (0.06 log units) below what was measured; measured number inside the range.
By their numbers in this assay, from the lowest: compounds 1, 3 and 4 (each within the scatter of the next); then compound 2.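

In this assay, among the compounds shown here, methoxy in place of methyl on an aromatic carbon, meta to a large group, gives numbers within the scatter of each other (a 1.1-fold higher number from compound 3 to compound 4 (0.02 log units; within the scatter)), so the first oxygen-bearing group at this position reads like methyl. The 3-methoxyphenyl compound also falls within the scatter of the 2-methylphenyl compound (a 1.4-fold higher number from compound 1 to compound 4 (0.16 log units; within the scatter)), while 4-methylbenzyl remains clearly apart (a 5.1-fold lower number from compound 2 to compound 4 (0.70 log units; beyond the scatter)). No evidence at hand accounts for these readings. Open, on these data alone, is whether an amine, a carboxylic acid or a longer chain such as ethoxy at this position would separate from methyl and methoxy.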